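Cyclopentyl for Methyl on the Ketone Side Chain

The source may hold more compounds than are shown below. What is called first, only, known or untested is meant among the compounds shown, and "the series" means these compounds.

Compound 2 `CCC(=O)c1ccc(OCCCCOc2ccc(C(=O)O)cc2C)c(C)c1O` was run in an assay on HEK293 cells for positive allosteric modulation of metabotropic glutamate receptor 3 (Rattus norvegicus), read by thallium flux, with a stated time of 2.5 min (on this read-out lower numbers stand for an effect already at smaller amounts and higher numbers for an effect only at larger amounts of compound), where compound 2 gives "not determined" (no result reported), so it offers no number to stand on. Compound 3 `Cc1cc(C(=O)O)ccc1OCCCCOc1ccc(C(=O)CC2CCCC2)c(O)c1C` carries cyclopentyl in place of methyl on a saturated chain carbon bound to a carbonyl carbon. For the measured compounds named here, no measured pair tells how large such a step should be, and with nothing known for compound 2 no direction can be read from it. Going by the values given here, the only measured anchor is compound 1 `COc1ccc(C(=O)O)cc1OCCCCOc1ccc(C(=O)CC2CCCC2)c(O)c1C`, which in this assay gives 1020 nM. Compound 3 is therefore expected to come out near 1000 nM, within a range from 300 nM to 3500 nM.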

Compound 3, half-maximal effective concentration: > 10000 nM
Compound 3 was reported as a limit; the forecaster's own chance of this, stated with the estimate: 15%; at least 10-fold (1.00 log units) between middle value and limit.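

In this assay compound 3 is reported only as a limit, not as a number: the limit of > 10000 nM in this assay, at which 1 of the 3 values shown sits. With the cyclopentyl side chain held the same, changing only the group on an oxygen on a saturated carbon gives an at least 9.8-fold higher number from compound 1 to compound 3 (0.99 log units; beyond the scatter), so cyclopentyl alone does not secure the value seen for compound 1. Compound 2 has no number, so the step from methyl to cyclopentyl cannot be read. Still open, as far as these compounds go, is how a cyclohexyl on that chain carbon, or an amide in place of the carboxylic acid, would read out.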